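A few compounds are considered here, and "the series" means these few. Any claim that something is new, unique, unknown or untested is made for them only; others in the source may bear on it.

Measured in a functional assay on MDA-MB-231 cells (Homo sapiens) for antiproliferative activity, read by sulforhodamine B assay, with a stated time of 72 h; on this read-out lower numbers stand for stronger inhibition and higher numbers for weaker inhibition:
- Compound 1 `COc1ccc(/C=C2\CCC=CC2=O)cc1`: 1620 nM
- Compound 2 `O=C1C=CCC/C1=C\c1ccc(OC(F)(F)F)cc1`: 590 nM
- Compound 3 `O=C1C=CCC/C1=C\c1ccc(-c2ccccc2)cc1`: not yet measured

Of the two measured compounds, compound 2 holds the lower number, 590 nM. Compound 3 carries phenyl in place of trifluoromethoxy on an aromatic carbon, para to a group of 8 heavy atoms: phenyl in place of trifluoromethoxy on an aromatic carbon. Going by the values given here, the one measured step bearing on this, a 2.7-fold lower number from compound 1 to compound 2 (0.44 log units; beyond the scatter), was modest and involved a different pair of groups. Among the compounds with values here, no measured step involves phenyl, so no large change is expected in this assay, and the direction remains open. The expected step is a 1.2-fold lower number from compound 2 to compound 3 (0.07 log units; within the scatter), which does not go beyond the scatter. The estimate for compound 3 is 500 nM, within a range of 170 nM to 1500 nM.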

Compound 3, half-maximal inhibitory concentration: 680 nM
Estimate against measurement, compound 3: 1.4-fold (0.13 log units) below, and the stated range covers the measured number.
By their numbers in this assay, from the lowest: compounds 2 and 3 (each within the scatter of the next); then compound 1.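

In this assay this place on the aromatic ring does not separate phenyl from trifluoromethoxy (a 1.2-fold higher number from compound 2 to compound 3 (0.06 log units; within the scatter)). A group with a six-membered aromatic ring of carbon only and no hydrogen-bond acceptor thus keeps the gain over methoxy (a 2.4-fold lower number from compound 1 to compound 3 (0.38 log units; beyond the scatter)). Nothing measured here explains why these two different groups give numbers within the scatter of each other. On these data alone, whether an amine or a carboxylic acid at this place would fit the same way stays open, as does the effect of a chlorine on the added phenyl.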